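From 3-Chlorophenyl to 4-Chlorophenyl

The source may hold more compounds than are shown below. What is called first, only, known or untested is meant among the compounds shown, and "the series" means these compounds.

Measured in an assay on isolated protein for displacement of a labelled ligand from secreted frizzled-related protein 1 (Homo sapiens), read by fluorescence polarization, with a stated time of 30 min; a lower number here means a stronger inhibitor, a higher number a weaker inhibitor:
Compound 1 `O=C(c1ccccc1)N1CCC(NS(=O)(=O)c2cc(S(=O)(=O)c3ccccc3)ccc2C(F)(F)F)CC1` gives 70 nM
Compound 2 `O=C(c1cccc(Cl)c1)N1CCC(NS(=O)(=O)c2cc(S(=O)(=O)c3ccccc3)ccc2C(F)(F)F)CC1` gives 300 nM

Among the compounds with values here, compound 2 stands at the higher of the two numbers, the single measured step being a 4.3-fold higher number from compound 1 to compound 2 (0.63 log units; beyond the scatter). Compound 3 `O=C(c1ccc(Cl)cc1)N1CCC(NS(=O)(=O)c2cc(S(=O)(=O)c3ccccc3)ccc2C(F)(F)F)CC1` differs from compound 2 by 4-chlorophenyl in place of 3-chlorophenyl on a carbonyl carbon. Within the data shown here, no measured pair shifts a chlorine from one position to another, so only the step from compound 1 to compound 2 bears here, and it offers no guide to direction. With nothing pointing either way, the expected step of a 1.2-fold lower number from compound 2 to compound 3 (0.08 log units; within the scatter) lies within the scatter, though wide uncertainty remains. Compound 3 is estimated at 250 nM, with a range from 70 nM to 900 nM.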

Compound 3, half-maximal inhibitory concentration: 300 nM
Compound 3: middle estimate off by 1.2-fold (0.08 log units), on the low side; the range from low to high includes it.
By their numbers in this assay, from the lowest: compound 1; then compounds 2 and 3 (each within the scatter of the next).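

In this assay, moving the chlorine from 3-chlorophenyl to 4-chlorophenyl gives no change at the digits printed from compound 2 to compound 3 (within the scatter) and so does not separate these two placements. Compared with the unsubstituted compound, the 4-chlorophenyl group gives a 4.3-fold higher number from compound 1 to compound 3 (0.63 log units; beyond the scatter) and matches the rise already seen with 3-chlorophenyl, so among these compounds both chloro placements sit above compound 1. No available evidence explains this shared rise.

Going by these compounds, it remains open whether the rise belongs to chlorine itself or to any added group on this ring. A methoxy group or an amine at the same places could answer that.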